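A few compounds are considered here, and "the series" means these few. Any claim that something is new, unique, unknown or untested is made for them only; others in the source may bear on it.

Working notes on the series. Compound 2 `COc1ccc(-c2cc(-c3ccc(Cl)cc3)n[nH]2)cc1` gives 12800 nM in a functional assay on OVCAR cells (Homo sapiens) for inhibition, read by MTT assay, with a stated time of 48 h; a lower number here means a stronger inhibitor of growth, a higher number a weaker inhibitor of growth; compound 1 `COc1ccc(-c2cc(-c3ccccc3)n[nH]2)cc1` gives 9900 nM, and the step of a 1.3-fold higher number from compound 1 to compound 2 (0.11 log units; within the scatter) is within the scatter, so the two numbers stand together. Compound 3 `COc1ccc(-c2cc(-c3ccc(Br)cc3)n[nH]2)cc1` differs from compound 2 by bromo in place of chloro on an aromatic carbon. For the measured compounds named here, the only measured step that bears on a halogen at this aromatic carbon is a 1.3-fold higher number from compound 1 to compound 2 (0.11 log units; within the scatter), which stayed within the scatter. No step beyond the scatter is expected in this assay, which is what a 1.1-fold lower number from compound 2 to compound 3 (0.03 log units; within the scatter) means. Compound 3 is therefore estimated at 12000 nM, with a range from 6000 nM to 25000 nM.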

Compound 3, concentration for 50% growth inhibition: 20700 nM
Beside the measured number, compound 3's estimate is 1.7-fold (0.24 log units) below it; measured number inside the range.
By their numbers in this assay, from the lowest: compounds 1, 2 and 3 (each within the scatter of the next, the first and the last beyond it).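

In this assay, bromo in place of chloro on this aromatic carbon gives a 1.6-fold higher number from compound 2 to compound 3 (0.21 log units; within the scatter) and leaves the two halogens together. Bromo in place of hydrogen gives a 2.1-fold higher number from compound 1 to compound 3 (0.32 log units; beyond the scatter) and is the first step at this position beyond the scatter, though a modest one, so the only change seen here so far is toward weaker growth inhibition. Nothing available explains this step.

From the compounds shown here alone, whether an amine or a carboxylic acid on this carbon would give a lower number remains open. So does whether fluoro would stand with hydrogen or with bromo.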